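The source may report more compounds than this note shows. Statements on the series, on what has been measured and on what is new or still open speak of the compounds shown alone.

Measured so far in a physicochemical assay for solubility, with a stated time of 18 h, at pH 7.4; a higher number here means a more soluble compound, a lower number a less soluble compound:
compound 1 `COc1cccc(CNCCCNc2ccnc3cc(C4CCCCC4)ccc23)c1O`, 4200 nM
compound 2 `COc1ccc(F)cc1CNCCCNc1ccnc2cc(C3CCCCC3)ccc12`, 4200 nM
compound 3 `COc1ccccc1Oc1ccc2c(NCCCNCc3ccco3)ccnc2c1`, 14500 nM

Compound 2 stands level with compound 1 at the digits shown; together they hold the lowest of the three numbers, and compound 3 lies highest, the gap from compound 2 to compound 3 being beyond the scatter. Among the compounds with values here, the only step between measured neighbours, no change at the digits printed from compound 1 to compound 2 (within the scatter), exchanges the aryl group on the saturated chain carbon bound to an amine nitrogen and leaves the number where it was.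

Compound 4 `COc1ccc(F)cc1CNCCCNc1ccnc2cc(-c3ccc(C(F)(F)F)cc3)ccc12` differs from compound 2 at a different site: 4-(trifluoromethyl)phenyl in place of cyclohexyl on an aromatic carbon. No measured step touches this position; the one shown step concerns another part of the molecule and was flat, so it gives no direct guidance, and compound 3 differs from compound 2 in several places at once. With nothing to anchor it, the expectation for compound 4 is a number near that of compound 2, carrying a wide range, with the step of a 1.7-fold lower number from compound 2 to compound 4 (0.23 log units; within the scatter) expected to fall within or only just beyond the scatter. Compound 4 is therefore estimated at 2500 nM in this assay, between 800 nM and 8000 nM.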

Compound 4, solubility: 32000 nM
Compound 4: middle estimate off by 13-fold (1.11 log units), on the low side; the measured number lies above the stated range.
By their numbers in this assay, from the lowest: compounds 1 and 2 (each within the scatter of the next); then compound 3; then compound 4.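

Within the data shown here, the aromatic carbon that is meta to a fused ring and para to a fused ring is a site that moves the read-out in this assay: 4-(trifluoromethyl)phenyl in place of cyclohexyl gives a 7.6-fold higher number from compound 2 to compound 4 (0.88 log units; beyond the scatter), whereas the only earlier step, at another site, was flat at no change at the digits printed from compound 1 to compound 2 (within the scatter). The exchange puts a six-membered aromatic ring bearing trifluoromethyl where a six-membered non-aromatic ring stood, with more heavy atoms and the same count of hydrogen-bond donors and acceptors, and in this single pair the larger group goes with the higher number. Nothing at hand accounts for this rise.

This one pair cannot separate the contribution of the aromatic ring from that of the trifluoromethyl group, and plain phenyl or 4-methoxyphenyl on the same carbon would begin to pull the two apart. Going by these compounds, it also remains open whether the step carries over when 2-hydroxy-3-methoxyphenyl replaces 5-fluoro-2-methoxyphenyl on the chain, and whether a ring holding an amine, such as piperidine, would behave in the same way at this position.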